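Dropping the Chloro Group: What the Numbers Suggest

The source may report more compounds than this note shows. Statements on the series, on what has been measured and on what is new or still open speak of the compounds shown alone.

Compound 1 `O=C(/C=C/c1cccc([N+](=O)[O-])c1)c1ccc2ccccc2c1` — 13000 nM
Compound 2 `O=C(/C=C/c1cccc(Cl)c1)c1ccc2ccccc2c1` — 23000 nM

In a functional assay on L1210 cells (Mus musculus) for cytotoxicity, read by MTT assay, with a stated time of 48 h (a lower number here means a stronger inhibitor, a higher number a weaker inhibitor), compound 1 gives 13000 nM and compound 2 gives 23000 nM. The step of a 1.8-fold higher number from compound 1 to compound 2 (0.25 log units; within the scatter) lies within the scatter, so compound 2 stands highest of the two numbers only nominally, with compound 1 nearest. Compound 3 `O=C(/C=C/c1ccccc1)c1ccc2ccccc2c1` differs from compound 2 by hydrogen in place of chloro on an aromatic carbon. Among the compounds with values here, the one measured step at this position, a 1.8-fold higher number from compound 1 to compound 2 (0.25 log units; within the scatter), stayed within the scatter, so in this assay no step beyond the scatter is expected here. The expected step is a 1.1-fold higher number from compound 2 to compound 3 (0.04 log units; within the scatter). Compound 3 is therefore estimated at 25000 nM, within 10000 nM to 60000 nM.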

Compound 3, half-maximal inhibitory concentration: 20000 nM
Compound 3: the middle estimate sits 1.3-fold (0.10 log units) above what was measured; the range from low to high includes it.
By their numbers in this assay, from the lowest: compounds 1, 3 and 2 (each within the scatter of the next).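

Taking the chloro group off altogether (a 1.2-fold lower number from compound 2 to compound 3 (0.06 log units; within the scatter)) leaves the number within the scatter in this assay, and hydrogen in place of nitro (a 1.5-fold higher number from compound 1 to compound 3 (0.19 log units; within the scatter)) does the same. With the plain phenyl now measured, hydrogen, chloro and nitro on this aromatic carbon cannot be told apart, so none of the three is shown to matter here. No evidence is available to explain this result.

As far as these compounds go, whether an amine, a carboxylic acid or a longer chain on this carbon would give a step beyond the scatter remains open.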